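This account rests on a few compounds, and the source may have more. Where it says the series, first, only, none or still open, it means among the compounds named here.

In a functional assay on HCT-15 cells (Homo sapiens) for cytotoxicity, read by CCK-8 assay and cell counting, with a stated time of 2 days (a lower number here means a stronger inhibitor, a higher number a weaker inhibitor), the measured compounds and their values are these:

compound 1 `Oc1ccc(-c2cc(-c3ccccn3)nc(-c3ccccc3Cl)c2)cc1` — compound 1 gives "not determined" (no result reported);
compound 2 `Oc1ccc(-c2cc(-c3cccc(Cl)c3)nc(-c3ccccn3)c2)cc1` — compound 2 gives 28200 nM;
compound 3 `Oc1cccc(-c2cc(-c3cccc(Cl)c3)nc(-c3ccccn3)c2)c1` — compound 3 gives "not determined" (no result reported).

Among the measured compounds shown here, compound 2 therefore stands alone: it carries the only number in this assay, while compound 1 and compound 3 were run without a reported result. For the measured compounds named here, no pair of measured compounds differs in a single place, so no step size can be read from the measured set.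

Compound 4 `Oc1ccc(-c2cc(-c3ccccc3)nc(-c3cccc(Cl)c3)c2)cc1` differs from compound 2 by the change (phenyl in place of pyridin-2-yl on an aromatic carbon), phenyl in place of pyridin-2-yl on an aromatic carbon. Going by the values given here, since no measured step of comparable kind exists, the expectation for this change is a step no larger than the usual scatter, in no fixed direction. Compound 4 is estimated at 30000 nM in this assay, with a range from 10000 nM to 90000 nM. The step expected from compound 2 is a 1.1-fold higher number from compound 2 to compound 4 (0.03 log units; within the scatter), judged to stay within the scatter.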

Compound 4, half-maximal inhibitory concentration: 6100 nM
Compound 4: the middle estimate sits 4.9-fold (0.69 log units) above what was measured; measured number below the stated range.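

In this assay, phenyl in place of pyridin-2-yl on the aromatic carbon next to the ring nitrogen gives a 4.6-fold lower number from compound 2 to compound 4 (0.66 log units; beyond the scatter), the only step that can be read among these compounds. It shows that the number responds to which six-membered aromatic ring stands at this position, even though the two groups have the same count of heavy atoms and differ in the one ring nitrogen and its hydrogen-bond acceptor. No measurement shown accounts for this step, so its cause remains unknown.

The compounds shown leave open how an amine or a carboxylic acid on this phenyl would affect the number. They also leave open whether the step would hold with the 4-hydroxyphenyl or 3-chlorophenyl group changed, since compound 1 and compound 3 offer no number for comparison.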